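This account rests on a few compounds, and the source may have more. Where it says the series, first, only, none or still open, it means among the compounds named here.

The measured compounds are these:
compound 1, `CCOC(=O)c1c(-c2c(Cl)c3ccccc3oc2=O)nn(-c2ccccc2)c1C(=O)OCC`, which in a functional assay on A549 cells (Homo sapiens) for cytotoxicity, read by MTT assay, with a stated time of 48 h (a higher number here means a weaker inhibitor, a lower number a stronger inhibitor), gives 34000 nM;
compound 2, `CCOC(=O)c1c(-c2c(Cl)c3cc(C)ccc3oc2=O)nn(-c2ccccc2)c1C(=O)OCC`, which in this assay gives 108000 nM;
compound 3, `CCOC(=O)c1c(-c2cc3cc(OC)ccc3oc2=O)nn(-c2ccccc2)c1C(=O)OCC`, which in this assay gives 35000 nM.

Between compound 1 and compound 2 the single difference is methyl in place of hydrogen on an aromatic carbon, and that step reads a 3.2-fold higher number from compound 1 to compound 2 (0.50 log units; beyond the scatter). Compound 3 carries a different core; how its core differs from that of compound 1 is not broken down here. The values of compound 3 and compound 1 in this assay lie within the usual scatter of each other, so the two show no separation that can be relied on.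

Compound 4, `CCOC(=O)c1c(-c2cc3cc(OC)ccc3oc2=O)nn(-c2cccc(C)c2)c1C(=O)OCC`, has not yet been measured. It differs from compound 3 by methyl in place of hydrogen on an aromatic carbon. This is the same kind of change as that from compound 1 to compound 2, but not the same: there the methyl enters a ring that is part of a fused or bridged system of two rings, meta to a fused ring and para to a fused ring, whereas in compound 4 it enters a six-membered aromatic ring of carbon only, meta to a large group. Among the measured compounds shown here, because a 3.2-fold higher number from compound 1 to compound 2 (0.50 log units; beyond the scatter) went toward a higher number, a higher number is also expected for compound 4, though a smaller step is expected, since the place of the change is not the same and only one earlier instance exists. The expected step is a 1.7-fold higher number from compound 3 to compound 4 (0.23 log units; within the scatter). In this assay compound 4 is expected to give 60000 nM, with a likely range from 25000 nM to 150000 nM.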

Compound 4, half-maximal inhibitory concentration: 102000 nM
Compound 4: middle estimate off by 1.7-fold (0.23 log units), on the low side, and the stated range covers the measured number.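

In this assay, the step from phenyl to 3-methylphenyl reads a 2.9-fold higher number from compound 3 to compound 4 (0.46 log units; beyond the scatter), and it closely matches the earlier methyl step on the other core: the same change on two cores in this assay, a 3.2-fold higher number (0.50 log units; beyond the scatter) from compound 1 to compound 2 and a 2.9-fold higher number (0.46 log units; beyond the scatter) from compound 3 to compound 4, 1.1-fold (0.04 log units) apart, within the scatter of two such steps Within these two pairs, then, methyl in place of hydrogen on an aromatic carbon moved the number the same way and by a similar size, toward a weaker inhibitor, although in compound 2 the methyl enters a ring of a fused or bridged system and in compound 4 it enters a six-membered aromatic ring of carbon only, meta to a large group. This does not establish a rule for the series: there are only two instances, the core and the place of the methyl change together, so their contributions cannot be separated, and nothing here explains why the number rises.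

The compounds shown leave open whether the step would hold with the methyl at one same place on both cores, or on any further core. They also leave open what a longer chain, an amine or a carboxylic acid would do on the phenyl ring in place of the methyl.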